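The source may report more compounds than this note shows. Statements on the series, on what has been measured and on what is new or still open speak of the compounds shown alone.

Of the compounds shown here, two from this series have been measured so far. Compound 2 `Clc1ccc(C2=NN(c3nc(-c4ccc(Br)cc4)cs3)C(c3cccs3)C2)cc1` carries a 4-bromophenyl on the ring attached to the core, and in a functional assay on WM 266-4 cells (Homo sapiens) for antiproliferative activity, read by MTT assay, with a stated time of 48 h (on this read-out lower numbers stand for stronger inhibition and higher numbers for weaker inhibition), compound 2 gives 1450 nM. Compound 1 `Brc1ccc(C2=NN(c3nc(-c4ccccc4)cs3)C(c3cccs3)C2)cc1`, which carries an unsubstituted phenyl in the same place and a bromo rather than a chloro on the other aryl ring, gives in this assay a value of 1870 nM, and the two numbers sit within the usual scatter of each other, so neither compound can be called the more active.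

Compound 3 `Clc1ccc(C2=NN(c3nc(-c4ccccc4)cs3)C(c3cccs3)C2)cc1` has not yet been measured. It differs from compound 2 in one place: hydrogen in place of bromo on an aromatic carbon, para to a large group, so that the 4-bromophenyl becomes a phenyl. For the measured compounds named here, no measured pair in this set shows that change in isolation. Since the two measured compounds differ by only a small amount despite two substituent changes, the step expected from compound 2 to compound 3 is small, a 1.2-fold higher number from compound 2 to compound 3 (0.07 log units; within the scatter), and not beyond the scatter in either direction. Compound 3 is therefore estimated to give about 1700 nM in this assay, within a range from 700 nM to 4200 nM.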

Compound 3, half-maximal inhibitory concentration: 2190 nM
For compound 3 the middle estimate is 1.3-fold (0.11 log units) below the measured one; measured number inside the range.
By their numbers in this assay, from the lowest: compounds 2, 1 and 3 (each within the scatter of the next).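

In this assay, hydrogen in place of bromo on an aromatic carbon, para to a large group, gives a 1.5-fold higher number from compound 2 to compound 3 (0.18 log units; within the scatter) and so stays within the scatter. For the compounds shown here, this is the first pair in which that change stands alone, and it shows that the 4-bromophenyl and the phenyl are not told apart at this position in this assay. Chloro in place of bromo on the other aryl ring gives a 1.2-fold higher number from compound 1 to compound 3 (0.07 log units; within the scatter) and is also within the scatter, so the two changes that lay together between compound 1 and compound 2 can now be read separately, and neither separates its pair. Nothing available here bears on why the numbers of these compounds lie so close together.

At the position para to the large group, the compounds shown hold only hydrogen and bromo, so it remains open whether an amine, a carboxylic acid or a methoxy group there would give a step beyond the scatter. The other aryl ring holds only chloro and bromo, which leaves open what a nitrile or a longer alkyl chain would do at that place.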